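The source may hold more compounds than are shown below. What is called first, only, known or untested is meant among the compounds shown, and "the series" means these compounds.

Working notes on the series, read in a physicochemical assay for solubility, at pH 7.4; a lower number here means a less soluble compound, a higher number a more soluble compound. Compound 1 `O=C(N[C@H]1CN(S(=O)(=O)c2ccccc2)C[C@@H]1C(=O)N[C@H]1CCCNC1)c1cn(C2CC2)cn1` gives 664000 nM, and compound 2 `O=C(N[C@H]1CN(S(=O)(=O)c2ccccc2)C[C@@H]1C(=O)N[C@H]1CCCNC1)c1cc(-c2ccccc2Cl)on1` gives 12000 nM, so compound 2 holds the lower of the two numbers. Compound 3 `O=C(N[C@H]1CN(S(=O)(=O)c2ccccc2)C[C@@H]1C(=O)N1C[C@H]2CCNC[C@H]21)c1cc(-c2ccccc2Cl)on1` keeps the rest of compound 2 and differs at one place only, on a carbonyl carbon whose other neighbours are: saturated ring carbon. The change there is a group of 8 heavy atoms (6 carbon, 2 nitrogen; one four-membered non-aromatic ring with 1 hetero atom, one six-membered non-aromatic ring with 1 hetero atom) in place of a group of 7 heavy atoms (5 carbon, 2 nitrogen; one six-membered non-aromatic ring with 1 hetero atom), on a carbonyl carbon.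

Among the measured compounds shown here, the only measured step, a 55-fold lower number from compound 1 to compound 2 (1.74 log units; beyond the scatter), is large and beyond the scatter. It exchanges a different group, however, and the (piperidin-3-yl)amino group stays in place throughout it. For the measured compounds named here, no measurement yet tests the group now being replaced, so the size of that step cannot be carried over to this one. What it does show is that the numbers in this series can move far, which argues for a wide range. No step beyond the scatter is expected in this assay, and no direction is favoured. The expected change is a 1.2-fold higher number from compound 2 to compound 3 (0.07 log units; within the scatter). Compound 3 is estimated at 14000 nM, with an expected range of 4500 nM to 42000 nM.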

Compound 3, solubility: 265000 nM
Beside the measured number, compound 3's estimate is 19-fold (1.28 log units) below it, and the stated range ends below it.
By their numbers in this assay, from the lowest: compound 2; then compound 3; then compound 1.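

In this assay, the place on a carbonyl carbon whose other neighbours are saturated ring carbon proves highly responsive: replacing the (piperidin-3-yl)amino group with the group carrying a four-membered and a six-membered non-aromatic ring gives a 22-fold higher number from compound 2 to compound 3 (1.34 log units; beyond the scatter). The earlier compounds shown here showed movement only at the other carbonyl carbon, with a 55-fold lower number from compound 1 to compound 2 (1.74 log units; beyond the scatter), so two places on the shared core now shift the number beyond the scatter, and the low number of compound 2 does not fix the level for compounds carrying the same isoxazole-side group. No measurement shown here gives a reason for the size or direction of this step.

This single exchange alters the ring count, the hydrogen-bond donor count and the number of defined stereocentres together, so the compounds shown do not separate these changes from one another. Also open, going by these compounds, is how a simple pyrrolidin-3-ylamino group or an open-chain 2-aminoethylamino group would read at this place, and whether the same exchange would give a comparable step with the group of compound 1 on the other carbonyl carbon.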